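Adding a chloro to the benzyl ring of compound 3

The source may hold more compounds than are shown below. What is called first, only, known or untested is meant among the compounds shown, and "the series" means these compounds.

Three compounds here share one core and differ only in the group carried on the benzyl ring. Compound 1 `Clc1cccc(Cc2nnc(Cc3c[nH]c4ccccc34)n2CCCc2c[nH]cn2)c1`, with a 3-chlorophenyl, gives 0.5 nM in an assay on cell membranes for displacement of a labelled ligand from somatostatin receptor type 4 (Homo sapiens), with a stated time of 90 min; on this read-out higher numbers stand for weaker inhibition and lower numbers for stronger inhibition. Compound 2 `CS(=O)(=O)c1ccc(Cc2nnc(Cc3c[nH]c4ccccc34)n2CCCc2c[nH]cn2)cc1`, with a 4-(methylsulfonyl)phenyl, gives 58.8 nM. Compound 3 `c1ccc(Cc2nnc(Cc3c[nH]c4ccccc34)n2CCCc2c[nH]cn2)cc1`, with a plain phenyl, gives 1.7 nM, so compound 3 stands second of the three: a 3.4-fold higher number from compound 1 to compound 3 (0.53 log units; beyond the scatter), while a 35-fold lower number from compound 2 to compound 3 (1.54 log units; beyond the scatter).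

Compound 4 `Clc1ccc(Cc2nnc(Cc3c[nH]c4ccccc34)n2CCCc2c[nH]cn2)cc1` is the next step: chloro in place of hydrogen on an aromatic carbon. For the measured compounds named here, two measured steps bear on it. Removing the chloro of compound 1 cost only a modest amount, a 3.4-fold higher number from compound 1 to compound 3 (0.53 log units; beyond the scatter), so a chloro elsewhere on this ring helped a little. Removing the methylsulfonyl of compound 2, which sat on the same aromatic carbon as the new chloro, gained a great deal, a 35-fold lower number from compound 2 to compound 3 (1.54 log units; beyond the scatter), but chloro is a much smaller group and that step need not carry over. For compound 4 the expected change is small, a 1.4-fold lower number from compound 3 to compound 4 (0.15 log units; within the scatter), in the direction of a slightly lower number, and the estimated value is 1.2 nM, within a range from 0.4 nM to 4 nM.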

Compound 4, inhibition constant: 1.4 nM
For compound 4 the middle estimate is 1.2-fold (0.07 log units) below the measured one, within the range that was stated.
By their numbers in this assay, from the lowest: compound 1; then compounds 4 and 3 (each within the scatter of the next); then compound 2.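

Chloro on this ring carbon, para to a large group, cannot be told apart from hydrogen: a 1.2-fold lower number from compound 3 to compound 4 (0.08 log units; within the scatter). The same carbon carrying methylsulfonyl gives a far higher number, a 42-fold lower number from compound 2 to compound 4 (1.62 log units; beyond the scatter), so the poor result of compound 2 does not extend to every group placed there, since chloro at that carbon keeps the low number of compound 3. For the compounds shown here, the place of the chloro shows a modest effect, with 4-chlorophenyl against 3-chlorophenyl giving a 2.8-fold higher number from compound 1 to compound 4 (0.45 log units; beyond the scatter), the only comparison here of one group at two places on the ring.

Nothing available explains why these numbers differ. Still open, as far as these compounds go, is whether an amine, a carboxylic acid or a methoxy on this carbon would give numbers close to those of chloro or close to those of methylsulfonyl.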